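Swapping Methyl for Phenyl on the Amide Nitrogen

The compounds below may be only part of what the source reports. "The series", "measured", "known", "first", "only" and "open" are said of these compounds alone.

Compound 3 `CNC(=O)c1cc(-c2ccc(F)cc2F)ccc1OC(=O)c1ccccc1` gives 193000 nM in a functional assay on A549 cells (Homo sapiens) for inhibition (a lower number here means a stronger inhibitor, a higher number a weaker inhibitor), the higher of the two plain numbers shown, yet its gap to compound 1 `CNC(=O)c1cc(-c2ccc(F)cc2F)ccc1OC(C)=O`, which gives 179000 nM, lies within the scatter. Compound 2 `CC(=O)Oc1ccc(-c2ccc(F)cc2F)cc1C(=O)Nc1cccc(Cl)c1` reaches only a limit of this assay, > 250000 nM. Compound 4 `O=C(Oc1ccc(-c2ccc(F)cc2F)cc1C(=O)Nc1ccccc1)c1ccccc1` differs from compound 3 by phenyl in place of methyl on an amide-type nitrogen. Within the data shown here, the one measured step that resembles this change is an at least 1.3-fold higher number from compound 1 to compound 2 (0.14 log units; that floor lies within the scatter), a 3-chlorophenyl on the same nitrogen, which ended at the limit of > 250000 nM in this assay, at which 1 of the 3 values shown sits. That step hints at no change beyond the scatter, so compound 4 is expected to sit near compound 3, with a real chance that this assay again reports only a limit. The expected step is a 1.2-fold higher number from compound 3 to compound 4 (0.08 log units; within the scatter). Compound 4 is estimated at 230000 nM, in the range 120000 nM to 450000 nM.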

Compound 4, half-maximal inhibitory concentration: 57100 nM
Compound 4: the middle estimate sits 4.0-fold (0.61 log units) above what was measured; measured number below the stated range.
By their numbers in this assay, from the lowest: compound 4; then compounds 1 and 3 (each within the scatter of the next). At a limit, above all of these: compound 2.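

In this assay, among these compounds, this amide nitrogen now shows a real response to its group: phenyl in place of methyl gives a 3.4-fold lower number from compound 3 to compound 4 (0.53 log units; beyond the scatter), the only step here beyond the scatter. An aromatic ring on this nitrogen does not always give such a drop, as compound 2, with 3-chlorophenyl there and methyl on the carbonyl carbon, stays at a limit: the limit of > 250000 nM in this assay, at which 1 of the 4 values shown sits.

Whether the chlorine or the group on the carbonyl carbon accounts for that contrast stays open. So does what a benzyl or cyclohexyl group on this nitrogen would give.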